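A few compounds are considered here, and "the series" means these few. Any claim that something is new, unique, unknown or untested is made for them only; others in the source may bear on it.

Within the data shown here, only two compounds built on a shared core have been tested so far in a functional assay on GBM3 cells (Homo sapiens) for antiproliferative activity, read by WST assay, with a stated time of 72 h; a higher number here means a weaker inhibitor, a lower number a stronger inhibitor. There, compound 1 (`O=C(Nc1cccc(F)c1)Nc1cc2ncncc2cc1OCc1ccccc1Cl`) gives 2400 nM, and compound 2 (`O=C(Nc1ccc(C(F)(F)F)cc1)Nc1cc2ncncc2cc1OCc1cccc(Cl)c1`) gives 5100 nM. Compound 2 therefore has the higher of the two numbers, which makes it the weaker inhibitor of the pair, by a gap beyond the usual scatter of repeated measurements. The next structure, compound 3 (`O=C(Nc1cccc(F)c1)Nc1cc2ncncc2cc1OCc1cccc(Cl)c1`), changes one group of compound 2 on an amide-type nitrogen, with 3-fluorophenyl in place of 4-(trifluoromethyl)phenyl (3-fluorophenyl in place of 4-(trifluoromethyl)phenyl on an amide-type nitrogen). Among the measured compounds shown here, no measured pair isolates this single change, so the best available guide is compound 1, which carries the same 3-fluorophenyl group and gives 2400 nM. With so little data, any forecast remains loose. A modest fall in the number is expected in this assay, estimated as a 1.8-fold lower number from compound 2 to compound 3 (0.26 log units; within the scatter), which would mean a somewhat stronger inhibitor, although the real change could stay within the scatter. Compound 3 is estimated to give 2800 nM, with an expected range from 1000 nM to 7000 nM.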

Compound 3, half-maximal inhibitory concentration: 8300 nM
For compound 3 the middle estimate is 3.0-fold (0.47 log units) below the measured one; measured number above the stated range.
By their numbers in this assay, from the lowest: compound 1; then compounds 2 and 3 (each within the scatter of the next).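

In this assay, putting 3-fluorophenyl in place of 4-(trifluoromethyl)phenyl on the amide-type nitrogen gives a 1.6-fold higher number from compound 2 to compound 3 (0.21 log units; within the scatter), so this pair cannot tell the two groups apart, even though they differ in size and in where the ring carries its substituent. The clearer result comes from the other end of the molecule: 3-chlorophenyl in place of 2-chlorophenyl on a saturated chain carbon bound to an oxygen on an aromatic ring gives a 3.5-fold higher number from compound 1 to compound 3 (0.54 log units; beyond the scatter), which means a weaker inhibitor and shows that this single change can be read on its own. Nothing at hand explains why either step has the size it does.

As far as these compounds go, the groups on the amide-type nitrogen are all fluorine-bearing phenyl rings, so it stays open how an amine, a carboxylic acid or a longer chain would behave there in this assay. From the compounds shown here alone, it also stays open whether the step from 2-chlorophenyl to 3-chlorophenyl would keep its size with 4-(trifluoromethyl)phenyl on the amide-type nitrogen.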